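Ring Amines on the Amide Nitrogen: Estimating Compound 4

The source may report more compounds than this note shows. Statements on the series, on what has been measured and on what is new or still open speak of the compounds shown alone.

Three compounds have so far been measured in a functional assay on the whole organism (strain Wistar) for inhibition, with Rattus norvegicus as the target, read by paw edema, with stated times of 60 min and 3 h, at a dose of 100 mg/kg by the oral route; a higher number here means more inhibition at the dose given (going by the name of the read-out), a lower number less inhibition:
compound 1 `COc1cc2c(cc1OC)C(CC(=O)N(C)C)CC2` gives 34.8%
compound 2 `COc1cc2c(cc1OC)C(CC(=O)NC(C)(C)C)CC2` gives 33.3%
compound 3 `COc1cc2c(cc1OC)C(CC(=O)NC1CCCC1)CC2` gives 43.5%

Compound 1 stands second highest of the three. Its nearest neighbour is compound 2, with a number 1.5 percentage points lower from compound 1 to compound 2 (within the scatter), and its furthest is compound 3, with a number 8.7 percentage points higher from compound 1 to compound 3 (within the scatter); neither gap counts as a real change. For the measured compounds named here, the only step beyond the scatter is a number 10.2 percentage points higher from compound 2 to compound 3 (beyond the scatter), a modest rise.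

Compound 4 `COc1cc2c(cc1OC)C(CC(=O)NC1CCCCC1)CC2` has not yet been measured. It differs from compound 1 as follows: cyclohexylamino in place of dimethylamino on a carbonyl carbon. Going by the values given here, the step that bears most directly on this is the one from compound 1 to compound 3, where a different ring amine replaced the same dimethylamino group and gave a number 8.7 percentage points higher from compound 1 to compound 3 (within the scatter). The step from compound 2 to compound 3, a number 10.2 percentage points higher from compound 2 to compound 3 (beyond the scatter), points the same way. A small upward move is therefore expected, though it may not clear the scatter. Compound 4 is estimated at 42%, within 30% to 54%, which is expected to mean a number 7.2 percentage points higher from compound 1 to compound 4 (within the scatter).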

Compound 4, a percentage reported as inhibition, in the whole organism at one dose (the size of the read-out at that dose, not a potency): 49.3%
Beside the measured number, compound 4's estimate is 7.3 percentage points below it; low and high end bracket the measured number.
By their numbers in this assay, from the lowest: compounds 2, 1, 3 and 4 (each within the scatter of the next, the first and the last beyond it).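

In this assay, swapping dimethylamino for a ring amine on the carbonyl carbon now gives a step beyond the scatter, a number 14.5 percentage points higher from compound 1 to compound 4 (beyond the scatter), which the cyclopentylamino amide did not. The cyclohexyl amide also stands clear of the open-chain tert-butyl amide, with a number 16 percentage points higher from compound 2 to compound 4 (beyond the scatter), while the ring size itself cannot be separated, with a number 5.8 percentage points higher from compound 3 to compound 4 (within the scatter), so the two ring amides read alike. No measurement here explains these differences.

Going by these compounds, whether cycloheptyl, a phenyl ring or a longer chain such as n-hexyl on the amide nitrogen would match the cyclohexyl amide remains open. The role of the amide hydrogen is also unsettled, and an N-methyl-N-cyclohexyl amide would test it, while a single dose gives no measure of potency for any of these compounds.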